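Trading 4-methoxycyclohexyl for cyclobutyl in compound 4

This account rests on a few compounds, and the source may have more. Where it says the series, first, only, none or still open, it means among the compounds named here.

Half-lives measured in an ADME assay on microsomes from liver (Mus musculus) for metabolic stability, read by LC-MS, using NADPH, with a stated time of 10 min, tested at 10 uM; a lower number here means that the compound disappears faster, a higher number that the compound lasts longer:
- Compound 1 `N#Cc1ccnc(Oc2nn(C3CCC3)c3ncnc(N)c23)c1`: 0.4 h
- Compound 2 `Nc1ncnc2c1c(Oc1cc(C(F)(F)F)ccn1)nn2C1CC1`: > 2.41 h, a limit of the assay
- Compound 3 `CO[C@H]1CC[C@@H](n2nc(Oc3cc(C(F)(F)F)ccn3)c3c(N)ncnc32)CC1`: 0.0333 h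

Compound 3 lasts the shortest time of the three, and its gap to compound 1 lies beyond the scatter. Compound 4 `Nc1ncnc2c1c(Oc1cc(C(F)(F)F)ccn1)nn2C1CCC1`, not yet measured, carries cyclobutyl in place of 4-methoxycyclohexyl on an aromatic nitrogen. The closest guide is the measured change at that same place, an at least 72-fold lower number from compound 2 to compound 3 (1.85 log units; beyond the scatter), a large step that brought in 4-methoxycyclohexyl. Taking that group away should therefore raise the number considerably. Compound 1 also carries cyclobutyl, with nitrile where compound 4 has trifluoromethyl, and compound 1 gives 0.4 h. The expected change is a 30-fold higher number from compound 3 to compound 4 (1.48 log units; beyond the scatter), well beyond the scatter. For compound 4 the estimated half-life is 1 h, expected within 0.3 h to 3 h.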

Compound 4, half-life: 0.128 h
Beside the measured number, compound 4's estimate is 7.8-fold (0.89 log units) above it, outside the stated range (below it).
By their numbers in this assay, from the lowest: compound 3; then compound 4; then compound 1. At a limit, above all of these: compound 2.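

Most of the drop seen with 4-methoxycyclohexyl on the aromatic nitrogen already appears with cyclobutyl: cyclobutyl in place of cyclopropyl gives an at least 18-fold lower number from compound 2 to compound 4 (1.27 log units; beyond the scatter), while cyclobutyl in place of 4-methoxycyclohexyl recovers only a 3.8-fold higher number from compound 3 to compound 4 (0.58 log units; beyond the scatter). With cyclobutyl held fixed, the other place also counts, since trifluoromethyl in place of cyano gives a 3.1-fold lower number from compound 1 to compound 4 (0.49 log units; beyond the scatter). The number for compound 2 is a limit of the assay: the limit of > 2.41 h in this assay, at which 1 of the 4 values shown sits.

On these data alone, whether an open-chain group such as isopropyl or a ring carrying an amine on that nitrogen would track cyclopropyl or cyclobutyl remains open. So does whether trifluoromethyl and nitrile keep their order with cyclopropyl.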